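The source may report more compounds than this note shows. Statements on the series, on what has been measured and on what is new or still open speak of the compounds shown alone.

Measured so far in a functional assay on MGC-803 cells (Homo sapiens) for inhibition, read by MTT assay, with a stated time of 48 h; on this read-out higher numbers stand for weaker inhibition and lower numbers for stronger inhibition:
compound 1 `COc1cc(N(Cc2nc3ccccc3[nH]2)S(=O)(=O)c2ccc(C)cc2)cc(OC)c1OC`: 1020 nM
compound 2 `COc1cc(N(Cc2nc3ccccc3[nH]2)S(=O)(=O)c2ccc(F)cc2)cc(OC)c1OC`: 5680 nM
compound 3 `COc1cc(N(Cc2nc3ccccc3[nH]2)S(=O)(=O)c2ccc(Br)cc2)cc(OC)c1OC`: 2190 nM

Compound 3 sits second highest of the three numbers, separated from the others by a 2.1-fold higher number from compound 1 to compound 3 (0.33 log units; beyond the scatter) and a 2.6-fold lower number from compound 2 to compound 3 (0.41 log units; beyond the scatter); both steps and a 5.6-fold higher number from compound 1 to compound 2 (0.75 log units; beyond the scatter) were modest and all concern only the group on the sulfonyl aryl.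

Compound 4 `COc1cc(N(Cc2nc3ccccc3[nH]2)C(=O)c2ccccc2)cc(OC)c1OC` differs from compound 3 by benzoyl in place of (4-bromophenyl)sulfonyl on a nitrogen on an aromatic ring. Going by the values given here, none of the measured steps touches this change, so no direction can be read from them; the series only shows that swaps on this side of the molecule have so far stayed modest. Compound 4 is therefore estimated at 2500 nM, with a wide range from 600 nM to 10000 nM. The expected step is a 1.1-fold higher number from compound 3 to compound 4 (0.06 log units; within the scatter).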

Compound 4, half-maximal inhibitory concentration: > 50000 nM
Compound 4: no number, only a limit (the forecaster's own chance of this, stated with the estimate: 5%); middle value at least 20-fold (1.30 log units) away from the limit.
By their numbers in this assay, from the lowest: compound 1; then compound 3; then compound 2. At a limit, above all of these: compound 4.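

Compound 4 has no number, only a limit of the assay: the limit of > 50000 nM in this assay, at which 1 of the 4 values shown sits. The nitrogen substituent therefore matters far more than the earlier swaps on the sulfonyl aryl suggested, with benzoyl in place of each (4-substituted phenyl)sulfonyl giving weaker inhibition: an at least 22-fold higher number from compound 3 to compound 4 (1.35 log units; beyond the scatter), an at least 8.8-fold higher number from compound 2 to compound 4 (0.94 log units; beyond the scatter) and an at least 49-fold higher number from compound 1 to compound 4 (1.69 log units; beyond the scatter). All three sulfonyl compounds keep measurable inhibition, while compound 4 does not reach a number.

Benzoyl differs from these groups both in the carbonyl and in its unsubstituted ring, so the two contributions remain unseparated. Phenylsulfonyl and 4-methylbenzoyl would separate them, and how a simple alkylsulfonyl on this nitrogen would read remains open.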